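This account rests on a few compounds, and the source may have more. Where it says the series, first, only, none or still open, it means among the compounds named here.

In an assay on L cells for inhibition of Protein-serine O-palmitoleoyltransferase porcupine (Mus musculus), read by reporter gene assay, with a stated time of 24 h (on this read-out lower numbers stand for an effect already at smaller amounts and higher numbers for an effect only at larger amounts of compound), three compounds of this series have been measured so far. Compound 1 `COc1ccc2nc(NC(=O)CNC(=O)c3nn(-c4ccccc4OC)c(=O)c4ccccc34)sc2c1` gives 90 nM in this assay. Compound 2 `O=C(CSc1nc2c(c(=O)n1-c1ccccc1)SCC2)Nc1ccc(-c2ccccn2)cc1` gives 4 nM, and compound 3 `COc1ccc2nc(NC(=O)CSc3nc4c(c(=O)n3-c3ccccc3)SCC4)ccc2c1` gives 580 nM. Among these three numbers compound 1 holds the second highest: compound 3 sits above it by a gap beyond the usual scatter, and compound 2 sits below it by a still larger gap, also beyond the scatter. Compound 4 `COc1ccc2nc(NC(=O)CNC(=O)c3nn(-c4ccc(F)cc4)c(=O)c4ccccc34)sc2c1` has not yet been measured. It differs from compound 1 in a single place, (4-fluorophenyl in place of 2-methoxyphenyl on an aromatic nitrogen), the new group standing on an aromatic nitrogen of the shared core. For the measured compounds named here, no measured pair in this set shows what such an exchange does, so any expectation rests on compound 1 alone and on the size of the change. The step expected here, a 1.3-fold lower number from compound 1 to compound 4 (0.11 log units; within the scatter), is small and stays within the scatter. Compound 4 is accordingly estimated at 70 nM in this assay, within a range from 20 nM to 250 nM.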

Compound 4, half-maximal effective concentration: 90 nM
For compound 4 the middle estimate is 1.3-fold (0.11 log units) below the measured one; low and high end bracket the measured number.
By their numbers in this assay, from the lowest: compound 2; then compounds 1 and 4 (each within the scatter of the next); then compound 3.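

In this assay, replacing 2-methoxyphenyl with 4-fluorophenyl on the aromatic nitrogen gives no change at the digits printed from compound 1 to compound 4 (within the scatter). For the compounds shown here, this is the first pair that differs in one place, and it shows that at this position the read-out holds when the group loses its hydrogen-bond acceptor and takes on a fluorine instead. Nothing measured here bears on why the two groups read alike.

Because the methoxy group and the fluorine change together, the pair does not separate the effect of one from the other, and a plain phenyl group would be needed to do so. On these data alone, whether a group of another kind on this nitrogen, such as an aminophenyl, a carboxyphenyl or a longer alkyl chain, would leave the number in place also remains open.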